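Does the bromo matter to compound 2?

The compounds below may be only part of what the source reports. "The series", "measured", "known", "first", "only" and "open" are said of these compounds alone.

Measured so far in a functional assay, with a stated time of 30 min; on this read-out lower numbers stand for stronger inhibition and higher numbers for weaker inhibition:
Compound 1 `CCCCCCOc1cc(OC)c(Br)cc1C(C)=O` gives 42400000 nM
Compound 2 `CCCCCCCCOc1cc(OC)c(Br)cc1C(C)=O` gives 39000000 nM
Compound 3 `CCCCCCCCCCCCCCOc1cc(OC)c(Br)cc1C(C)=O` gives 16100000 nM

Compound 2 holds the middle place among these three numbers, though its gap to one neighbour lies within the scatter (a 1.1-fold lower number from compound 1 to compound 2 (0.04 log units; within the scatter)) and its gap to the other does not (a 2.4-fold lower number from compound 2 to compound 3 (0.38 log units; beyond the scatter)). Compound 4 `CCCCCCCCOc1cc(OC)ccc1C(C)=O` makes a single change (hydrogen in place of bromo on an aromatic carbon), hydrogen in place of bromo on an aromatic carbon. Both of those measured steps lengthen the chain and keep the bromo, so neither gauges this change directly. With no measured guide, no step beyond the scatter is expected in this assay, though with wide uncertainty. The expected step is small (a 1.0-fold higher number from compound 2 to compound 4 (0.01 log units; within the scatter)). Compound 4 is estimated at 40000000 nM (expected range 14000000 nM to 110000000 nM).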

Compound 4, half-maximal inhibitory concentration: 40000000 nM
Compound 4: middle estimate and measured number agree at the digits printed, and the stated range covers the measured number.
By their numbers in this assay, from the lowest: compound 3; then compounds 2, 4 and 1 (each within the scatter of the next).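

In this assay, hydrogen in place of bromo gives a 1.0-fold higher number from compound 2 to compound 4 (0.01 log units; within the scatter) and so leaves the number within the scatter. This aromatic carbon, ortho to a methoxy group and meta to an acetyl group, can therefore lose its bromo on the core of compound 2 without a measurable change, something the chain steps could not show. No measured evidence here offers an explanation for this result.

An amine or a carboxylic acid at this carbon remains untested among the compounds shown. So does the same change on the longer chain of compound 3.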